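Swapping the nitrogen cap of a pyrazoline-type core

The source may hold more compounds than are shown below. What is called first, only, known or untested is meant among the compounds shown, and "the series" means these compounds.

Of the compounds shown here, three sharing one core have been tested in an ADME assay on HepG2 cells (Homo sapiens) for cytotoxicity, read by MTT assay, with a stated time of 24 h, tested at 5 uM; a higher number here means a weaker effect of the compound at the concentration tested, a lower number a stronger effect. Compound 1 `COc1cc(C2=NNC(c3ccc(Cl)cc3)C2)ccc1O` carries a hydrogen on the ring nitrogen and gives 94.6%. Compound 2 `COc1cc(C2=NN(S(=O)(=O)c3ccc(C)cc3)C(c3ccc(Cl)cc3)C2)ccc1O` gives 79.6%, and compound 3 `COc1cc(C2=NN(C(=S)Nc3ccccc3)C(c3ccc(Cl)cc3)C2)ccc1O` gives 88.2%. Compound 3 thus stands second highest of the three, with compound 1 nearest and compound 2 furthest, both within the scatter.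

Compound 4 `COc1cc(C2=NN(C(=O)Oc3ccccc3)C(c3ccc(Cl)cc3)C2)ccc1O` differs from compound 3 in one place: a group of 9 heavy atoms (7 carbon, 2 oxygen; one six-membered aromatic ring of carbon only) in place of a group of 9 heavy atoms (7 carbon, 1 nitrogen, 1 sulfur; one six-membered aromatic ring of carbon only), on an amine nitrogen in a ring.

Among the compounds with values here, no measured step covers this exact exchange. Within the data shown here, the steps that bear on it all change the group on the same ring nitrogen: a number 15 percentage points lower from compound 1 to compound 2 (beyond the scatter), a number 6.4 percentage points lower from compound 1 to compound 3 (within the scatter) and a number 8.6 percentage points higher from compound 2 to compound 3 (within the scatter). Only the first lies beyond the scatter; the other two do not. On this basis compound 4 is expected to land close to compound 3, with a step of a number 3.2 percentage points lower from compound 3 to compound 4 (within the scatter) that is not expected to exceed the scatter. The estimate for compound 4 in this assay is 85%, with a range from 72% to 96%.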

Compound 4, a percentage reported as activity, at one concentration (the size of the read-out at that concentration, not a potency): 81.7%
Estimate against measurement, compound 4: 3.3 percentage points above; low and high end bracket the measured number.
By their numbers in this assay, from the lowest: compounds 2, 4, 3 and 1 (each within the scatter of the next, the first and the last beyond it).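

In this assay the phenoxycarbonyl group on the ring nitrogen stays close to the two other large groups: replacing the group of compound 3 gives a number 6.5 percentage points lower from compound 3 to compound 4 (within the scatter) and replacing the (4-methylphenyl)sulfonyl group gives a number 2.1 percentage points higher from compound 2 to compound 4 (within the scatter) in this set. The exchange from compound 3 removes the hydrogen-bond donor of the leaving group, yet its step stays within the scatter. Within the data shown here, replacing the hydrogen of the parent gives a number 12.9 percentage points lower from compound 1 to compound 4 (beyond the scatter) and is the only new step that clears the scatter, so compound 4 joins compound 2 in standing apart from compound 1, while compound 3 does not.

No measurement shown here explains these differences.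

As far as these compounds go, it remains open whether a small acetyl or methyl group on this nitrogen would read like the hydrogen of compound 1 or like the larger groups. The same question holds for a group carrying an amine.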